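The source may hold more compounds than are shown below. What is called first, only, known or untested is meant among the compounds shown, and "the series" means these compounds.

Measured so far in a functional assay on HeLa cells (Homo sapiens) for antiproliferative activity, read by CCK-8 assay, with a stated time of 48 h; a higher number here means a weaker inhibitor, a lower number a stronger inhibitor:
Compound 1 `O=c1c2ccccc2[se]n1-c1nc(SCc2ccccc2)n[nH]1`, which gives only the assay limit > 50000 nM.
Compound 2 `CCCCSc1n[nH]c(-n2[se]c3ccccc3c2=O)n1`, which gives 32900 nM.
Compound 3 `CCSc1n[nH]c(-n2[se]c3ccccc3c2=O)n1`, which gives 14100 nM.

Compound 3 holds the lowest of the two numbers, with compound 2 nearest at a 2.3-fold lower number from compound 2 to compound 3 (0.37 log units; beyond the scatter). Compound 4 `CC(C)CSc1n[nH]c(-n2[se]c3ccccc3c2=O)n1` differs from it by isopropyl in place of methyl on a saturated chain carbon bound to a sulfur. Within the data shown here, the steps that bear on this all concern the chain on the sulfur: an at least 1.5-fold lower number from compound 1 to compound 2 (0.18 log units; that floor lies within the scatter), an at least 3.5-fold lower number from compound 1 to compound 3 (0.54 log units; beyond the scatter) and a 2.3-fold lower number from compound 2 to compound 3 (0.37 log units; beyond the scatter), where the shorter chain gave the lower number and the longer chain a modestly higher one. A step of similar size upward is therefore expected, a 2.0-fold higher number from compound 3 to compound 4 (0.30 log units; within the scatter). Compound 4 is estimated at 28000 nM, within 12000 nM to 65000 nM.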

Compound 4, half-maximal inhibitory concentration: 34900 nM
Compound 4: the middle estimate sits 1.2-fold (0.10 log units) below what was measured; low and high end bracket the measured number.
By their numbers in this assay, from the lowest: compound 3; then compounds 2 and 4 (each within the scatter of the next). At a limit, above all of these: compound 1.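

In this assay, ethylsulfanyl keeps its advantage over isobutylsulfanyl, with a 2.5-fold higher number from compound 3 to compound 4 (0.39 log units; beyond the scatter). Branching gives no separation from the unbranched longer chain, with a 1.1-fold higher number from compound 2 to compound 4 (0.03 log units; within the scatter). Against the benzyl chain only an at least 1.4-fold lower number from compound 1 to compound 4 (0.15 log units; that floor lies within the scatter) can be stated, and that step rests on an assay limit: the limit of > 50000 nM in this assay, at which 1 of the 4 values shown sits.

From the compounds shown here alone, whether a shorter group, such as methyl on the sulfur, would lower the number further remains open. Also open, going by these compounds, is what an amine or a carboxylic acid at the chain end would do.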